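The compounds below may be only part of what the source reports. "The series", "measured", "known", "first", "only" and "open" are said of these compounds alone.

Three compounds share a core built around a thiocarbonyl carbon that carries a ring nitrogen, and all three were tested in a functional assay on A-431 cells (Homo sapiens) for cytotoxicity, read by MTT assay, with a stated time of 72 h, tested at 1 uM; on this read-out higher numbers stand for more inhibition of growth at the one concentration tested and lower numbers for less inhibition of growth. Compound 2 `N/C(=N\NC(=S)N1CCCC1)c1ccc(F)cn1` gives 50.7% in this assay, the highest of the three numbers. Compound 3 `Cc1cccc(/C(N)=N/NC(=S)N2CCCCC2)n1` gives 35% in this assay, a number lower than that of compound 2 by more than the usual scatter. Compound 1 `N/C(=N\NC(=S)N1CCN(c2ccccn2)CC1)c1ccc(F)cn1` gives 31.1% in this assay, the number furthest from compound 2 and also beyond the scatter. Compound 2 therefore stands alone at the top of the measured set.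

Compound 4 `N/C(=N\NC(=S)N1CCSCC1)c1ccc(F)cn1` has not yet been measured. It differs from compound 2 in one place: thiomorpholin-4-yl in place of pyrrolidin-1-yl on a thiocarbonyl carbon. Within the data shown here, no measured pair shows exactly this exchange, so any expectation rests on the three numbers alone. Both compounds carrying a six-membered ring on the thiocarbonyl carbon, compound 1 and compound 3, sit below compound 2, although compound 3 also differs from compound 2 elsewhere in its structure, so the comparison is loose. On that basis compound 4 is expected to land somewhat below compound 2. The expected step is a number 12.7 percentage points lower from compound 2 to compound 4 (beyond the scatter), a downward move of moderate size, with wide uncertainty. In this assay compound 4 is estimated at 38%, in a range from 22% to 55%.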

Compound 4, percent growth inhibition at one concentration: 48.7%
Beside the measured number, compound 4's estimate is 10.7 percentage points below it; the measured number falls inside the stated range.
By their numbers in this assay, from the lowest: compounds 1 and 3 (each within the scatter of the next); then compounds 4 and 2 (each within the scatter of the next).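

In this assay, thiomorpholin-4-yl in place of pyrrolidin-1-yl on a thiocarbonyl carbon gives a number 2 percentage points lower from compound 2 to compound 4 (within the scatter), so this position accepts the exchange with no change that can be told from the usual variation between repeats. Among these compounds, this is the first pair in the set that differs in one place only, and it shows that a six-membered ring carrying a sulfur atom and a five-membered ring without one read alike here, so a six-membered ring on this carbon is not enough on its own to bring the number down. No measurement of any other kind is available to explain why the two rings read alike.

The compounds shown leave open whether the same holds for morpholin-4-yl, with oxygen where compound 4 has sulfur, or for an open-chain group such as diethylamino on the same carbon. They also leave open whether the match between compound 2 and compound 4 would persist at other concentrations, since each compound is represented here by a single reading at one concentration.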